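Thiophene for methoxyphenyl on an anilino-pyrimidine cytotoxicity series

This account rests on a few compounds, and the source may have more. Where it says the series, first, only, none or still open, it means among the compounds named here.

Measured so far:
compound 1 `COc1ccc(-c2ccnc(Nc3cccc(C(N)=O)c3)n2)cc1` gives 6700 nM
compound 2 `COc1ccc(-c2ccnc(Nc3ccc(C(N)=O)cc3)n2)cc1` gives 5300 nM
compound 3 `Cc1csc(-c2ccnc(Nc3ccc(C(N)=O)cc3)n2)c1` gives 30000 nM

In a functional assay on A549 cells (Homo sapiens) for cytotoxicity, read by MTT assay, with a stated time of 72 h (on this read-out lower numbers stand for stronger inhibition and higher numbers for weaker inhibition), compound 1 and compound 2 return numbers that are within the scatter of each other, so no order between them can be read. The two contain the same atoms joined differently; the difference between their cores is not broken down here. Compound 3 differs from compound 2 in one place, (4-methylthiophen-2-yl in place of 4-methoxyphenyl on an aromatic carbon), and this change gave a 5.7-fold higher number from compound 2 to compound 3 (0.75 log units; beyond the scatter).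

Compound 4 `Cc1csc(-c2ccnc(Nc3cccc(C(N)=O)c3)n2)c1` is not yet measured. It differs from compound 1 by 4-methylthiophen-2-yl in place of 4-methoxyphenyl on an aromatic carbon, the same change as from compound 2 to compound 3, at a place described in the same words. Going by the values given here, with only one earlier example of this change, the expectation rests on a single step. Compound 4 is therefore expected to move from compound 1 by a 5.7-fold higher number from compound 1 to compound 4 (0.75 log units; beyond the scatter) in this assay, close to the size seen in a 5.7-fold higher number from compound 2 to compound 3 (0.75 log units; beyond the scatter), since compound 1 starts from 6700 nM. The estimate for compound 4 is 38000 nM, expected to lie between 15000 nM and 95000 nM.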

Compound 4, half-maximal inhibitory concentration: > 100000 nM
Compound 4 gave a limit, no number; the forecaster's own chance of this, stated with the estimate: 20%; middle value at least 2.6-fold (0.42 log units) from the limit.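

In this assay, compound 4 gives > 100000 nM, which is a limit of the assay and not a number. Putting 4-methylthiophen-2-yl in place of 4-methoxyphenyl on the core of compound 1 gave an at least 14-fold higher number from compound 1 to compound 4 (1.17 log units; beyond the scatter), so with two examples in hand, the change raised the number on both cores, and each time beyond the scatter. The direction of the change therefore carried from one core to the other in these two pairs, but this does not show that its size carried as well, as only a lower bound is known for the second step: the same change on two cores in this assay, a 5.7-fold higher number (0.75 log units; beyond the scatter) from compound 2 to compound 3 and an at least 14-fold higher number (1.17 log units; beyond the scatter) from compound 1 to compound 4; the limit leaves it open whether they differ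

The compounds shown leave open how other groups at this place would behave on either core, such as a plain phenyl or a thiophene without its methyl. They also leave open what a carboxylic acid or a nitrile in place of the amide would do to the number.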